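Methyl on the thioether carbon of compound 3

This account rests on a few compounds, and the source may have more. Where it says the series, first, only, none or still open, it means among the compounds named here.

The shared core carries an amino group and a methylpiperazine, and differs among these compounds in the side chain. Compound 1 `CC(Oc1cccc(Cl)c1)c1nc(N)nc(N2CCN(C)CC2)n1` gives 118 nM in an assay on HEK293 cells for displacement of a labelled ligand from 5-hydroxytryptamine receptor 6 (Homo sapiens), read by radioligand binding, with a stated time of 1 h; a higher number here means a weaker inhibitor, a lower number a stronger inhibitor. Among the compounds with values here, compound 2 `CC(Oc1ccccc1Cl)c1nc(N)nc(N2CCN(C)CC2)n1` gives 23 nM in this assay, and the step of a 5.1-fold lower number from compound 1 to compound 2 (0.71 log units; beyond the scatter) is the only single-point change measured so far. Compound 3 `CN1CCN(c2nc(N)nc(CSc3ccccc3Cl)n2)CC1`, in which a sulfur links the chloro-substituted ring to the core through an unsubstituted saturated carbon, gives 126 nM and stands highest of the three numbers, with compound 1 within the scatter of it and compound 2 well below it.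

Compound 4 `CC(Sc1ccccc1Cl)c1nc(N)nc(N2CCN(C)CC2)n1` differs from compound 3 by methyl in place of hydrogen on a saturated chain carbon bound to an aromatic carbon and a sulfur. Within the data shown here, no measured step covers this exact change: the move from compound 1 to compound 2 concerns the position of the chlorine, not the saturated carbon. Compound 2 and compound 3 differ in two places at once, so their values can only be read together: the oxygen-linked, methyl-bearing compound 2 sits well below the sulfur-linked, unsubstituted compound 3.

Compound 4 is therefore expected to fall between them, with a step of a 2.5-fold lower number from compound 3 to compound 4 (0.40 log units; beyond the scatter) toward a lower number. The estimate for compound 4 in this assay is 50 nM, within a range from 15 nM to 160 nM.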

Compound 4, inhibition constant: 19 nM
Beside the measured number, compound 4's estimate is 2.6-fold (0.42 log units) above it; the range from low to high includes it.
By their numbers in this assay, from the lowest: compounds 4 and 2 (each within the scatter of the next); then compounds 1 and 3 (each within the scatter of the next).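

In this assay, within the data shown here, methyl in place of hydrogen on the saturated chain carbon bound to an aromatic carbon and a sulfur gives a 6.6-fold lower number from compound 3 to compound 4 (0.82 log units; beyond the scatter) and is the first measured single change at this carbon, showing that this one added carbon alone brings the sulfur-linked side chain to within the scatter of compound 2. With the methyl present, (2-chlorophenyl)sulfanyl in place of 2-chlorophenoxy gives a 1.2-fold lower number from compound 2 to compound 4 (0.08 log units; within the scatter) and so shows no difference beyond the scatter between the sulfur and oxygen links, whereas a 6.2-fold lower number from compound 1 to compound 4 (0.79 log units; beyond the scatter) combines that change of link with a change of chlorine position and cannot be assigned to either one. The data offer no independent measurement that explains the size of the methyl step.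

The compounds shown leave open what the same methyl does on the oxygen-linked side chain, where no unsubstituted partner for compound 2 stands among them. They also leave open how an ethyl or a hydroxyl on this saturated carbon would compare with the methyl of compound 4.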